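The source may hold more compounds than are shown below. What is called first, only, known or untested is meant among the compounds shown, and "the series" means these compounds.

Measured in a functional assay on HL-60 cells (Homo sapiens) for inhibition, read by CCK-8 assay, with a stated time of 48 h, tested at 20 uM; a higher number here means more inhibition of growth at the concentration tested, a lower number less inhibition of growth:
- compound 1 `N#C/C(=C\c1ccccc1OS(=O)(=O)c1ccccc1[N+](=O)[O-])C(=O)Nc1nnc(Cc2ccccc2)s1`: 12%
- compound 2 `N#C/C(=C\c1ccccc1OS(=O)(=O)c1ccccc1[N+](=O)[O-])C(=O)Nc1nnc(Cc2ccc(F)cc2)s1`: 35%
- compound 3 `Cc1ccc(Cc2nnc(NC(=O)/C(C#N)=C/c3ccccc3OS(=O)(=O)c3ccc(C)cc3)s2)cc1`: 17%

Compound 3, at 17%, lies within the usual scatter of compound 1 and clearly under compound 2. Compound 4 `Cc1ccc(Cc2nnc(NC(=O)/C(C#N)=C/c3ccccc3OS(=O)(=O)c3ccccc3[N+](=O)[O-])s2)cc1` differs from compound 3 by 2-nitrophenyl in place of 4-methylphenyl on a sulfonyl sulfur. For the measured compounds named here, no measured step makes this swap. The only one, a number 23 percentage points higher from compound 1 to compound 2 (beyond the scatter), is a different change, fluoro in place of hydrogen on an aromatic carbon. Compounds 1 and 2 already carry the entering group, so it is seen with both a low and a higher number. In this assay, no shift beyond the scatter is therefore expected, and the estimated step is a number 5 percentage points higher from compound 3 to compound 4 (within the scatter). The estimate for compound 4 is 22%, ranging from 8% to 40%.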

Compound 4, percent growth inhibition at one concentration: 33%
For compound 4 the middle estimate is 11 percentage points below the measured one; the measured number falls inside the stated range.
By their numbers in this assay, from the lowest: compounds 1 and 3 (each within the scatter of the next); then compounds 4 and 2 (each within the scatter of the next).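

In this assay the sulfonyl sulfur proves sensitive to its aromatic group, as 2-nitrophenyl in place of 4-methylphenyl moves the number (a number 16 percentage points higher from compound 3 to compound 4 (beyond the scatter)). With 2-nitrophenyl kept, methyl in place of hydrogen on the far aromatic ring also counts (a number 21 percentage points higher from compound 1 to compound 4 (beyond the scatter)), while methyl in place of fluoro does not (a number 2 percentage points lower from compound 2 to compound 4 (within the scatter)). No evidence on why these changes act as they do is available.

Going by these compounds, whether the step needs the nitro group itself or only the loss of 4-methylphenyl stays open. A plain phenyl or an aminophenyl on the sulfonyl sulfur would help separate the two.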